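From Methyl to Trifluoromethyl at the Assay Limit

The source may hold more compounds than are shown below. What is called first, only, known or untested is meant among the compounds shown, and "the series" means these compounds.

Compound 1 `Cc1cc(Nc2ccn(Cc3csc4ccc(Cl)cc34)n2)n2nc(SCc3ccc(Br)cc3)nc2n1` gives 4350 nM in a functional assay on PC-9 cells (Homo sapiens) for inhibition, read by MTT assay, with a stated time of 72 h (a lower number here means a stronger inhibitor, a higher number a weaker inhibitor), and compound 2 `Cc1cc(Nc2ccn(Cc3nc(C)c4ccccc4n3)n2)n2nc(SCc3ccc(Br)cc3)nc2n1` gives 5450 nM there (a 1.3-fold higher number from compound 1 to compound 2 (0.10 log units; within the scatter)). Compound 3 `Cc1ccc(Cn2ccc(Nc3cc(C)nc4nc(SCc5ccc(Br)cc5)nn34)n2)cc1` stands at > 50000 nM as a limit of the assay and not a number.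

Compound 4 `Cc1cc(Nc2ccn(Cc3ccc(C(F)(F)F)cc3)n2)n2nc(SCc3ccc(Br)cc3)nc2n1` carries trifluoromethyl in place of methyl on an aromatic carbon, para to a large group, where compound 3 has methyl (trifluoromethyl in place of methyl on an aromatic carbon). Among the compounds with values here, two measured steps touch this part of the molecule, but both exchange the whole group: 4-methylphenyl replaces 5-chloro-1-benzothiophen-3-yl (an at least 11-fold higher number from compound 1 to compound 3 (1.06 log units; beyond the scatter)) and 4-methylquinazolin-2-yl (an at least 9.1-fold higher number from compound 2 to compound 3 (0.96 log units; beyond the scatter)). Within the data shown here, both lie beyond the scatter, yet no measured step changes only the group on this ring. A far smaller edit is therefore expected to bring a modest move toward a lower number, or none beyond the scatter, and the result may well remain at the limit. The estimated change is small (an at least 1.6-fold lower number from compound 3 to compound 4 (0.22 log units; that floor lies within the scatter)). In this assay the estimate for compound 4 is 30000 nM with a range from 7000 nM to 60000 nM (expected, not measured).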

Compound 4, half-maximal inhibitory concentration: 5580 nM
Beside the measured number, compound 4's estimate is 5.4-fold (0.73 log units) above it, outside the stated range (below it).
By their numbers in this assay, from the lowest: compounds 1, 2 and 4 (each within the scatter of the next). At a limit, above all of these: compound 3.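

In this assay, one small edit on the benzyl ring, trifluoromethyl in place of methyl, gives an at least 8.9-fold lower number from compound 3 to compound 4 (0.95 log units; beyond the scatter), so this single group matters far more here than compound 3 alone could show. With 4-(trifluoromethyl)phenyl in this place, the single ring sits level with both larger groups, as a 1.0-fold higher number from compound 2 to compound 4 (0.01 log units; within the scatter) and a 1.3-fold higher number from compound 1 to compound 4 (0.11 log units; within the scatter) show. The size of the methyl step is only a floor, because compound 3 stands at a limit of the assay and not at a number: the limit of > 50000 nM in this assay, at which 1 of the 4 values shown sits.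

Whether trifluoromethyl is special or whether other groups at this place would serve as well stays open, since the compounds shown hold no chlorine, methoxy or nitrile there. They also cannot tell how an unsubstituted benzyl would compare.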